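This account rests on a few compounds, and the source may have more. Where it says the series, first, only, none or still open, it means among the compounds named here.

Among the compounds with values here, compound 1, with the structure `Nc1cc(N)c2nc(-c3ccccc3)c(NCc3ccc(Cl)c(Cl)c3)nc2c1`, is one of two compounds measured here. In a functional assay on NCI-H460 cells (Homo sapiens) for inhibition, read by sulforhodamine B assay, with a stated time of 48 h (on this read-out higher numbers stand for weaker inhibition of growth and lower numbers for stronger inhibition of growth), compound 1 gives 20900 nM, the lowest of the two numbers, which means it inhibits growth the most strongly of the pair. The other measured compound, compound 2, with the structure `CCOC(=O)[C@H](CCC(=O)O)NC(=O)c1ccc(Oc2nc3cc(N)cc(N)c3nc2-c2ccccc2)cc1`, gives in this assay a value of 95500 nM, a gap that lies beyond the usual scatter of repeated measurements.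

Compound 3, with the structure `COc1ccc(CNc2nc3cc(N)cc(N)c3nc2-c2ccccc2)cc1`, has not yet been measured. It differs from compound 1 in a single place: 4-methoxyphenyl in place of 3,4-dichlorophenyl on a saturated chain carbon bound to a nitrogen on an aromatic ring. Within the data shown here, no pair of measured compounds shows what such a swap does here, so any expectation rests on compound 1 alone. The step from compound 1 to compound 3 in this assay is expected to be small, most likely a little toward weaker inhibition, and may well fall within the scatter, as a 1.5-fold higher number from compound 1 to compound 3 (0.19 log units; within the scatter). Compound 3 is therefore estimated in this assay at 32000 nM, within a range from 8000 nM to 130000 nM.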

Compound 3, concentration for 50% growth inhibition: 20400 nM
Beside the measured number, compound 3's estimate is 1.6-fold (0.20 log units) above it; measured number inside the range.
By their numbers in this assay, from the lowest: compounds 3 and 1 (each within the scatter of the next); then compound 2.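

In this assay, putting 4-methoxyphenyl in place of 3,4-dichlorophenyl on a saturated chain carbon bound to a nitrogen on an aromatic ring gives a 1.0-fold lower number from compound 1 to compound 3 (0.01 log units; within the scatter) and so leaves the two compounds indistinguishable. Within the data shown here, this is the first single-place comparison in the set, and it shows that this position can hold either of these two substituted phenyl groups with no readable difference in growth inhibition. Nothing measured on these compounds explains this result.

Because the two chlorines and the methoxy group differ in both identity and placement on the ring, the effect of each alone remains unresolved. Going by these compounds, it also remains open whether an unsubstituted phenyl, a ring carrying an amine or a carboxylic acid, or a longer chain to the ring would fare the same.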